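Swapping a methyl for a trifluoromethyl on a phenylpiperazine

A few compounds are considered here, and "the series" means these few. Any claim that something is new, unique, unknown or untested is made for them only; others in the source may bear on it.

Of the compounds shown here, three sharing one core have been measured in an ADME assay on microsomes from liver (Rattus norvegicus) for metabolic stability, read by LC-MS, using NADPH; on this read-out lower numbers stand for a shorter-lived compound and higher numbers for a longer-lived compound. Compound 1 `O=C(NCCCCN1CCN(c2ccccc2)CC1)c1ccc(-c2ccsc2)cc1` gives 0.41 h. Compound 2 `O=C(NCCCCN1CCN(c2ccc(Cl)cc2Cl)CC1)c1ccc(-c2ccsc2)cc1` gives 0.3 h. Compound 3 `Cc1cccc(N2CCN(CCCCNC(=O)c3ccc(-c4ccsc4)cc3)CC2)c1` gives 0.372 h, which places it second highest of the three, nearest to compound 1 and furthest from compound 2, with both gaps within the scatter. Among the compounds with values here, of the steps seen so far, a 1.1-fold lower number from compound 1 to compound 3 (0.04 log units; within the scatter) and a 1.2-fold higher number from compound 2 to compound 3 (0.09 log units; within the scatter) are the ones that alter the same ring on the amine nitrogen, and a 1.4-fold lower number from compound 1 to compound 2 (0.14 log units; within the scatter) also changed only that ring; none of them moved the number beyond the scatter.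

Compound 4 `O=C(NCCCCN1CCN(c2cccc(C(F)(F)F)c2)CC1)c1ccc(-c2ccsc2)cc1` differs from compound 3 in one place: trifluoromethyl in place of methyl on an aromatic carbon. Since every change to this ring so far has stayed within the scatter, the expected step in this assay is small as well, a 1.1-fold higher number from compound 3 to compound 4 (0.03 log units; within the scatter), with no clear direction. Compound 4 is therefore estimated at 0.4 h, in a range from 0.2 h to 0.8 h.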

Compound 4, half-life: 0.282 h
Compound 4: middle estimate off by 1.4-fold (0.15 log units), on the high side; the range from low to high includes it.
By their numbers in this assay, from the lowest: compounds 4, 2, 3 and 1 (each within the scatter of the next).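

In this assay, trifluoromethyl, with four heavy atoms where methyl has one, stays within the scatter on this aromatic carbon, meta to a large group (a 1.3-fold lower number from compound 3 to compound 4 (0.12 log units; within the scatter)). The same holds when compound 4 is set against the unsubstituted phenyl (a 1.5-fold lower number from compound 1 to compound 4 (0.16 log units; within the scatter)) and against the 2,4-dichlorophenyl ring (a 1.1-fold lower number from compound 2 to compound 4 (0.03 log units; within the scatter)), so hydrogen, methyl and trifluoromethyl at this place cannot be told apart on this read-out, and all four ring variants sit within the scatter of the next. Nothing measured here bears on why this ring change leaves the half-life so little moved.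

On these data alone, whether an amine or a carboxylic acid on this same carbon would also stay within the scatter remains open. So does whether a longer chain in the shared core would move the half-life beyond it.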